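The source may report more compounds than this note shows. Statements on the series, on what has been measured and on what is new or still open speak of the compounds shown alone.

Of the compounds shown here, three sharing one core have been tested in an assay on HeLa cells for displacement of a labelled ligand from adenosine receptor A3 (Homo sapiens), read by scintillation counting, with a stated time of 180 min, tested at 10 uM; a higher number here means more inhibition at the concentration tested (going by the name of the read-out), a lower number less inhibition. Compound 1 `COc1cccc2cc(C(=O)Nc3c(C#N)ncn3-c3ccccc3)c(=N)oc12` gives 40%, compound 2 `COc1ccc(-n2cnc(C#N)c2NC(=O)c2cc3cccc(OC)c3oc2=N)cc1` gives 42%, and compound 3 `COc1cccc2cc(C(=O)Nc3c(C#N)ncn3-c3ccc(F)cc3)c(=N)oc12` gives 20%, the lowest of the three. The steps of a number 20 percentage points lower from compound 1 to compound 3 (beyond the scatter) and a number 22 percentage points lower from compound 2 to compound 3 (beyond the scatter) are both modest losses, while a number 2 percentage points higher from compound 1 to compound 2 (within the scatter) stays within the scatter. Compound 4 `COc1cccc2cc(C(=O)Nc3c(C#N)ncn3-c3ccc(C#N)cc3)c(=N)oc12` differs from compound 3 by cyano in place of fluoro on an aromatic carbon. Among the compounds with values here, no measured step involves cyano, so those two steps show only that a change at this position can matter, not where cyano will fall. Compound 4 is therefore expected to land somewhere between compound 3 and compound 1, with wide uncertainty. The estimate for compound 4 in this assay is 30%, ranging from 10% to 55%, an expected step of a number 10 percentage points higher from compound 3 to compound 4 (within the scatter).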

Compound 4, a percentage reported as inhibition, at one concentration (the size of the read-out at that concentration, not a potency): 1%
For compound 4 the middle estimate is 29 percentage points above the measured one, and the stated range ends above it.
By their numbers in this assay, from the lowest: compound 4; then compound 3; then compounds 1 and 2 (each within the scatter of the next).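

In this assay putting cyano on this aromatic carbon gives a number 19 percentage points lower from compound 3 to compound 4 (beyond the scatter) and so takes the number further down than fluoro did. Against the other two groups the change is larger, with a number 39 percentage points lower from compound 1 to compound 4 (beyond the scatter) and a number 41 percentage points lower from compound 2 to compound 4 (beyond the scatter) showing its size. Among the groups shown, fluoro and cyano both lower the number relative to hydrogen, while methoxy goes against this pattern. Nothing shown here gives a reason for these drops. Going by these compounds, whether an amine or a carboxylic acid at this position would raise the number or lower it remains open.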